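This account rests on a few compounds, and the source may have more. Where it says the series, first, only, none or still open, it means among the compounds named here.

Compound 1 `C/N=C(\S)NCCCCCn1nc(-c2ccccc2)ccc1=O` gives 35.3 mg/kg in a functional assay on the whole organism (stomach) with Rattus norvegicus as the target; on this read-out higher numbers stand for an effect only at larger amounts of compound and lower numbers for an effect already at smaller amounts. Compound 2 `CC/N=C(\S)NCCCn1nc(-c2ccccc2)ccc1=O` reaches only a limit of this assay, > 100 mg/kg. Among the compounds with values here, of the two values shown, compound 1 holds the only number, and the other is the limit of > 100 mg/kg in this assay, at which 1 of the 2 values shown sits. Within the data shown here, the single measured step, an at least 2.8-fold higher number from compound 1 to compound 2 (0.45 log units; beyond the scatter), alters the chain and the group on its far carbon. Compound 3 `CC/N=C(/NC#N)NCCCCCn1nc(-c2ccccc2)ccc1=O` differs from compound 1 instead by a group of 7 heavy atoms (4 carbon, 3 nitrogen; no ring) in place of a group of 4 heavy atoms (2 carbon, 1 nitrogen, 1 sulfur; no ring), on an amine nitrogen. That measured step therefore bears only loosely on this change, and no shift beyond the scatter is expected in this assay. Compound 3 is estimated at 30 mg/kg, with a range from 10 mg/kg to 100 mg/kg. Compound 3 is thus expected to show a 1.2-fold lower number from compound 1 to compound 3 (0.07 log units; within the scatter).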

Compound 3, dose for half-maximal effect: 100 mg/kg
Estimate against measurement, compound 3: 3.3-fold (0.52 log units) below; low and high end bracket the measured number.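

On an amine nitrogen whose other neighbour is a saturated chain carbon, the group alone changes here, with the chain of compound 1 kept, and in this assay this gives a 2.8-fold higher number from compound 1 to compound 3 (0.45 log units; beyond the scatter). Within the data shown here, the earlier step altered the chain and the group together, so only this step shows that the position responds to the group by itself. Compound 2 remains a limit, not a number: the limit of > 100 mg/kg in this assay, at which 1 of the 3 values shown sits.

The compounds shown leave open how a urea or an amine in place of either group would read on this chain. They also leave open whether a longer chain would shift the number.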